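The source may report more compounds than this note shows. Statements on the series, on what has been measured and on what is new or still open speak of the compounds shown alone.

Measured so far in a functional assay on HepG2 cells (Homo sapiens) for cytotoxicity, read by MTT assay, with a stated time of 72 h; on this read-out higher numbers stand for weaker inhibition and lower numbers for stronger inhibition:
- compound 1 `CN1[C@@H]2c3[nH]c4ccccc4c3C[C@H]1[C@H](C#N)N1[C@@H](CNC(=O)c3ccc(Cl)cc3)c3[nH]c4ccccc4c3C[C@@H]21`: 350 nM
- compound 2 `CN1[C@@H]2c3[nH]c4ccccc4c3C[C@H]1[C@H](C#N)N1[C@@H](CNC(=O)c3ccc4ccccc4c3)c3[nH]c4ccccc4c3C[C@@H]21`: 1210 nM

Among the measured compounds shown here, compound 2 stands at the higher of the two numbers; the nearest point is compound 1, and the only step recorded between them is a 3.5-fold higher number from compound 1 to compound 2 (0.54 log units; beyond the scatter), which exchanges the aryl group on the carbonyl carbon.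

Compound 3 `CN1[C@@H]2c3[nH]c4ccccc4c3C[C@H]1[C@H](C#N)N1[C@@H](CNC(=O)c3cc4ccccc4[nH]3)c3[nH]c4ccccc4c3C[C@@H]21` is the next variation at that same carbonyl carbon: 1H-indol-2-yl in place of naphthalen-2-yl on a carbonyl carbon. For the measured compounds named here, no step to compound 3 has been measured. Going by the values given here, the single step that bears on it is the one from compound 1 to compound 2, modest in size and beyond the scatter, showing that the aryl group on this carbonyl carbon does move the number in this assay. The indol-2-yl group keeps a two-ring aromatic system but brings one hydrogen-bond donor, so a shift back toward the number of compound 1 is plausible, though it may also stay within the scatter of compound 2. For compound 3 the expected step is a 1.7-fold lower number from compound 2 to compound 3 (0.24 log units; within the scatter). Compound 3 is estimated at 700 nM, with a range from 250 nM to 2000 nM.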

Compound 3, half-maximal inhibitory concentration: 440 nM
Compound 3: middle estimate off by 1.6-fold (0.20 log units), on the high side; the measured number falls inside the stated range.
By their numbers in this assay, from the lowest: compounds 1 and 3 (each within the scatter of the next); then compound 2.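

In this assay, a two-ring aryl group on this carbonyl carbon does not in itself go with the higher number: 1H-indol-2-yl in place of naphthalen-2-yl gives a 2.8-fold lower number from compound 2 to compound 3 (0.44 log units; beyond the scatter), so the step up seen earlier belongs to naphthalen-2-yl in this set and not to two-ring groups in general. The other comparison, a 1.3-fold higher number from compound 1 to compound 3 (0.10 log units; within the scatter), does not separate 1H-indol-2-yl from 4-chlorophenyl, so a one-ring and a two-ring aryl group are both compatible with the same range of numbers here. No evidence on hand explains these differences.

The compounds shown leave open whether the hydrogen on the indole nitrogen matters at this place, a question that 1-methyl-1H-indol-2-yl or benzofuran-2-yl on the same carbonyl carbon would address. They also leave open whether an aryl group is needed at all, as against a cyclohexyl group or a short alkyl chain.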